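Tetrazolyl-benzanilide series: a carbamoyl variant of compound 1

The source may report more compounds than this note shows. Statements on the series, on what has been measured and on what is new or still open speak of the compounds shown alone.

Measured so far:
- compound 1, `O=C(Nc1ccccc1)c1ccc(-c2nn[nH]n2)cc1`: 40 mg/kg
- compound 2, `CCCCc1ccc(C(=O)Nc2cc(C(=O)O)cc(C(=O)O)c2)cc1`: 91.9 mg/kg

In a functional assay on the whole organism (stomach) with Rattus norvegicus as the target (a lower number here means that less compound is needed, a higher number that more compound is needed for the effect), compound 1 gives 40 mg/kg, the lowest of the two numbers at hand. Compound 2 gives 91.9 mg/kg in this assay, a higher number, and the gap between compound 1 and compound 2 lies beyond the usual scatter. Among the measured compounds shown here, the two compounds differ in several places at once, so no single step between them can be read off; only the two values stand side by side.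

Compound 3, `NC(=O)c1ccc(NC(=O)c2ccc(-c3nn[nH]n3)cc2)cc1`, is the next compound and has not yet been measured in this assay. It keeps the whole of compound 1 and adds one group: carbamoyl in place of hydrogen on an aromatic carbon. The place is an aromatic carbon of the six-membered aromatic ring of carbon only, para to a large group.

For the measured compounds named here, no measured pair in the set shows a step of this kind, so the size of the step from compound 1 to compound 3 is not anchored by any data here. The expectation is a step of no more than the usual scatter in either direction, with the number for compound 3 close to that of compound 1; the step is estimated as a 1.1-fold lower number from compound 1 to compound 3 (0.06 log units; within the scatter). Compound 3 is thus expected to give about 35 mg/kg in this assay, within a range from 12 mg/kg to 100 mg/kg.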

Compound 3, dose for 50% inhibition: 33 mg/kg
Compound 3: the middle estimate sits 1.1-fold (0.03 log units) above what was measured; measured number inside the range.
By their numbers in this assay, from the lowest: compounds 3 and 1 (each within the scatter of the next); then compound 2.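

In this assay, carbamoyl in place of hydrogen on an aromatic carbon, para to a large group, gives a 1.2-fold lower number from compound 1 to compound 3 (0.08 log units; within the scatter), so this position of the core of compound 1 accepts a group of this size, with its hydrogen-bond donor and acceptor, without a step beyond the scatter. Among the compounds shown here, compound 1 and compound 2 differ in several places at once, so this is the first change that can be read at a single position, and it shows that the added carbamoyl leaves the dose needed for the effect indistinguishable from that of compound 1. No supporting measurement bears on this result, so the flat step stands as an observation without an explanation.

From the compounds shown here alone, whether the same position would also accept a carboxylic acid, an amine or a longer chain remains open, and such groups would show whether the flat step holds beyond carbamoyl. A single step at one place also says nothing about substitution elsewhere on the core of compound 1, where the same carbamoyl group could give a different result.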